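Bromo to Hydroxy on the Aryl Ring of Compound 2

The source may report more compounds than this note shows. Statements on the series, on what has been measured and on what is new or still open speak of the compounds shown alone.

Measured so far in a functional assay on U-87MG ATCC cells (Homo sapiens) for cytotoxicity, read by MTT assay, with a stated time of 72 h; a higher number here means a weaker inhibitor, a lower number a stronger inhibitor:
Compound 1 `CN(C)CCn1cnnc1-c1cc(Oc2ccc(NC(=O)N/N=C/c3c(Cl)cccc3Cl)cc2F)ccn1` gives > 100000 nM, which is a limit of the assay rather than a number.
Compound 2 `CN(C)CCn1cnnc1-c1cc(Oc2ccc(NC(=O)N/N=C/c3ccc(O)c(Br)c3)cc2F)ccn1` gives 12400 nM.
Compound 3 `COc1cc(/C=N/NC(=O)Nc2ccc(Oc3ccnc(-c4nncn4CCN(C)C)c3)c(F)c2)cc(OC)c1OC` gives 22500 nM.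

Compound 2 holds the lowest of the two numbers, but compound 3 sits only a 1.8-fold higher number from compound 2 to compound 3 (0.26 log units; within the scatter) away, within the scatter, so the two cannot be ordered. Compound 4 `CN(C)CCn1cnnc1-c1cc(Oc2ccc(NC(=O)N/N=C/c3ccc(O)c(O)c3)cc2F)ccn1` differs from compound 2 in one place: hydroxy in place of bromo on an aromatic carbon. Among the compounds with values here, no measured step swaps a bromo for a hydroxy. The steps of an at least 8.0-fold lower number from compound 1 to compound 2 (0.90 log units; beyond the scatter) and an at least 4.4-fold lower number from compound 1 to compound 3 (0.64 log units; beyond the scatter) show that two quite different groups on that ring both gave numbers well below the limit seen for compound 1, while a 1.8-fold higher number from compound 2 to compound 3 (0.26 log units; within the scatter) shows little separation between them. A small step, within the scatter, is therefore expected for compound 4 in this assay, a 1.2-fold higher number from compound 2 to compound 4 (0.08 log units; within the scatter). Compound 4 is estimated at 15000 nM, with a range from 5000 nM to 45000 nM.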

Compound 4, half-maximal inhibitory concentration: > 100000 nM
Compound 4 was reported as a limit; the forecaster's own chance of this, stated with the estimate: 10%; at least 6.6-fold (0.82 log units) between middle value and limit.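

In this assay, hydroxy in place of bromo on this ring gives an at least 8.0-fold higher number from compound 2 to compound 4 (0.90 log units; beyond the scatter) and is not a neutral swap. The 3,4-dihydroxyphenyl group also gives an at least 4.4-fold higher number from compound 3 to compound 4 (0.64 log units; beyond the scatter) on this same core, so not every group at this place keeps the number clear of the limit. Compound 4 gives a limit and not a number, one it shares with compound 1, so the step between those two cannot be read: the limit of > 100000 nM in this assay, at which 2 of the 4 values shown sit.

As far as these compounds go, whether an amine or a fluoro in place of the bromo would stay clear of that limit remains open.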